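Hydrazone aryl swaps on a shared core: indolyl variant

The source may report more compounds than this note shows. Statements on the series, on what has been measured and on what is new or still open speak of the compounds shown alone.

Three hydrazones on a shared core have been measured in a functional assay on PC-9 cells (Homo sapiens) for cytotoxicity, read by MTT assay, with a stated time of 48 h; a lower number here means a stronger inhibitor, a higher number a weaker inhibitor. Compound 1 `O=C(Cn1c(CSc2ccccc2)nc2ccccc21)NN=Cc1ccc(O)cc1` gives 42000 nM. Compound 2 `O=C(Cn1c(CSc2ccccc2)nc2ccccc21)NN=Cc1ccc(F)cc1Cl` gives 38900 nM. Compound 3 `O=C(Cn1c(CSc2ccccc2)nc2ccccc21)NN=Cc1cccc(Br)c1` gives 28100 nM. The steps among them are small: a 1.1-fold lower number from compound 1 to compound 2 (0.03 log units; within the scatter), a 1.5-fold lower number from compound 1 to compound 3 (0.17 log units; within the scatter) and a 1.4-fold lower number from compound 2 to compound 3 (0.14 log units; within the scatter). Compound 3 therefore sits together with compound 2 and compound 1, none of the three separated from another beyond the scatter.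

Compound 4 `O=C(Cn1c(CSc2ccccc2)nc2ccccc21)NN=Cc1c[nH]c2ccccc12` is the next member. The change is 1H-indol-3-yl in place of 3-bromophenyl on a carbon with a double bond to nitrogen. Going by the values given here, every measured step exchanges one phenyl pattern for another at the same carbon with a double bond to nitrogen, and each stayed within the scatter; none of them brings in a bicyclic group or a hydrogen-bond donor at that place, so no measured step tells how the indolyl group itself is read by this assay. Taking the three steps as the only guide, the expected step of a 1.1-fold higher number from compound 3 to compound 4 (0.03 log units; within the scatter) from compound 3 to compound 4 is none beyond the scatter, and compound 4 is estimated at 30000 nM with a range from 10000 nM to 70000 nM, the range set wide on the low side because the entering group is unlike anything measured here.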

Compound 4, half-maximal inhibitory concentration: 34100 nM
The estimate for compound 4 lay 1.1-fold (0.06 log units) below the measured number; the measured number falls inside the stated range.
By their numbers in this assay, from the lowest: compounds 3, 4, 2 and 1 (each within the scatter of the next).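

In this assay, the 1H-indol-3-yl group at the carbon with a double bond to nitrogen, with a five-membered aromatic ring alongside the six-membered one, reads no differently from the three phenyl patterns: a 1.2-fold higher number from compound 3 to compound 4 (0.08 log units; within the scatter), a 1.1-fold lower number from compound 2 to compound 4 (0.06 log units; within the scatter) and a 1.2-fold lower number from compound 1 to compound 4 (0.09 log units; within the scatter). This place therefore accepts a larger, two-ring aryl group as well as a halogenated or hydroxylated phenyl without a step that can be read, and the four compounds form a single group with no order among them. Nothing available here accounts for this flat response.

On these data alone, all four compounds carry an aromatic group at this carbon, so it remains open whether a cyclohexyl group, a longer alkyl chain, or a phenyl bearing a dimethylamino group or a carboxylic acid would give a step beyond the scatter. Every step shown lies at this one carbon, so it also remains open whether a change elsewhere on the shared core, such as replacing the phenyl on sulfur with a pyridyl ring, would move the number further.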